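A few compounds are considered here, and "the series" means these few. Any claim that something is new, unique, unknown or untested is made for them only; others in the source may bear on it.

Compound 1 `O[C@@H]1[C@@H](OCc2ccccc2)[C@H](OCc2ccccc2)[C@@H](COCc2ccccc2)O[C@H]1c1ccccc1`: 26300 nM
Compound 2 `CCC[C@@H]1O[C@H](COCc2ccccc2)[C@@H](OCc2ccccc2)[C@H](OCc2ccccc2)[C@H]1O`: 11700 nM
Compound 3 `OCCC[C@@H]1O[C@H](COCc2ccccc2)[C@@H](OCc2ccccc2)[C@H](OCc2ccccc2)[C@H]1O`: 19300 nM

All three values come from a functional assay on HL-60 cells (Homo sapiens) for antiproliferative activity, read by MTT assay; a lower number here means a stronger inhibitor, a higher number a weaker inhibitor. Compound 3 cannot be separated from either of the other two: there is a 1.4-fold lower number from compound 1 to compound 3 (0.13 log units; within the scatter), and there is a 1.6-fold higher number from compound 2 to compound 3 (0.22 log units; within the scatter). Among the measured compounds shown here, the only step beyond the scatter is a modest one, a 2.2-fold lower number from compound 1 to compound 2 (0.35 log units; beyond the scatter).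

The next compound, compound 4 `CC(C)(C)C[C@@H]1O[C@H](COCc2ccccc2)[C@@H](OCc2ccccc2)[C@H](OCc2ccccc2)[C@H]1O`, keeps the shared core of compound 3 and alters only the chain: tert-butyl in place of 2-hydroxyethyl on a saturated chain carbon bound to a saturated ring carbon. This places tert-butyl in place of 2-hydroxyethyl on a saturated chain carbon bound to a saturated ring carbon, so that 3-hydroxypropyl becomes neopentyl.

For the measured compounds named here, no measured compound carries a branched chain, so this exact change is untested. The nearest guide is compound 2, whose chain also lacks a hydroxy group and which gives 11700 nM. Removing that hydroxy group corresponds to the reverse of a 1.6-fold higher number from compound 2 to compound 3 (0.22 log units; within the scatter), a small step, and even replacing phenyl with propyl gave only a 2.2-fold lower number from compound 1 to compound 2 (0.35 log units; beyond the scatter). A step beyond the scatter is therefore not expected. The estimate means a 1.4-fold lower number from compound 3 to compound 4 (0.14 log units; within the scatter), an expected change that stays within the scatter. For compound 4 the expected value is 14000 nM, with an estimated range of 6500 nM to 28000 nM.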

Compound 4, half-maximal inhibitory concentration: "not active" (no number reported)
For compound 4 the study gives words and no number; no gap can be computed for the estimate.
By their numbers in this assay, from the lowest: compounds 2, 3 and 1 (each within the scatter of the next, the first and the last beyond it).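

Among the compounds shown here, compound 4 is reported in this assay only in words, as "not active", so no step between compound 4 and compound 3, or any other compound, can be read. Nothing given here accounts for this result. The compounds shown leave open how far a branched neopentyl chain truly differs from the straight chains of compound 2 and compound 3.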